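The source may hold more compounds than are shown below. What is called first, only, known or untested is meant among the compounds shown, and "the series" means these compounds.

Three compounds that share a sulfonamide linking two aromatic parts have been tested in an assay on isolated protein for inhibition of malate dehydrogenase, mitochondrial (Sus scrofa), with stated times of 45 min and 30 min; on this read-out higher numbers stand for weaker inhibition and lower numbers for stronger inhibition. Compound 3 `O=S(=O)(Nc1ccc2oc(-c3ccccc3)nc2c1)c1cccc(Cl)c1` carries a chloro group on one of its benzene rings. In this assay compound 3 gives > 63000 nM, which is a limit of the assay rather than a number. Compound 1 `O=S(=O)(Nc1ccc2oc(-c3ccccc3)nc2c1)c1cccc(C(F)(F)F)c1` differs from compound 3 by trifluoromethyl in place of chloro on an aromatic carbon. In this assay compound 1 gives > 63000 nM, again a limit. The step that the two limits leave unreadable from compound 3 to compound 1 therefore cannot be sized, since both of its ends sit at the limit of > 63000 nM in this assay, at which 3 of the 3 values shown sit.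

Compound 2 `O=S(=O)(Nc1ccc(-c2nc3ccccc3o2)cc1)c1cccc(Cl)c1` is built from the same atoms as compound 3, joined differently; the difference between the two cores is not broken down here. In this assay compound 2 gives > 63000 nM, which is a limit. Compound 4 `O=S(=O)(Nc1ccc(-c2nc3ccccc3o2)cc1)c1cccc(C(F)(F)F)c1` has not yet been measured. It differs from compound 2 by trifluoromethyl in place of chloro on an aromatic carbon, the same change as that leading from compound 3 to compound 1, made around the same place.

The step from compound 2 to compound 4 is expected to be a step that the limit leaves unreadable from compound 2 to compound 4. This expectation rests on compound 1, compound 2 and compound 3 all sitting at the limit of > 63000 nM in this assay, at which 3 of the 3 values shown sit, so the same change is unlikely to bring compound 4 into a readable range. For compound 4 the estimate in this assay is 100000 nM, within a range from 40000 nM to 300000 nM, and the assay is expected most likely to report only a limit once more.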

Compound 4, half-maximal inhibitory concentration: > 63000 nM
Compound 4: no number, only a limit (the forecaster's own chance of this, stated with the estimate: 85%); the middle value is on the limit's open side.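

In this assay compound 4 gives > 63000 nM, which is a limit and not a number. Compound 2 also sits at a limit, so no size can be read for the change from compound 2 to compound 4. The compounds shown leave open how strongly any of them inhibits the enzyme, and whether swapping chloro for trifluoromethyl makes any difference, because every value stops at the same point: the limit of > 63000 nM in this assay, at which 4 of the 4 values shown sit.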